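A non-aromatic ring replaces 3-fluorophenyl in compound 4

A few compounds are considered here, and "the series" means these few. Any claim that something is new, unique, unknown or untested is made for them only; others in the source may bear on it.

Measured in a functional assay on KYSE-70 cells for antiproliferative activity against KYSE-70 cell line (Homo sapiens), read by MTT assay, with a stated time of 72 h; a lower number here means a stronger inhibitor, a higher number a weaker inhibitor:
Compound 1 `COc1ccc(-c2ccc3c(C(=O)Nc4cccc(F)c4)cc(=O)[nH]c3c2)cc1`: > 20000 nM
Compound 2 `O=C(Nc1cccc(F)c1)c1cc(=O)[nH]c2cc(-c3ccsc3)ccc12`: 5100 nM
Compound 3 `O=C(Nc1cccc(F)c1)c1cc(=O)[nH]c2cc(-c3cccc(F)c3)ccc12`: 12000 nM

The entry for compound 1 is a limit of the assay and not a number. Of the two actual numbers, the higher belongs to compound 3, at 12000 nM.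

Compound 4 `O=C(Nc1cccc(F)c1)c1cc(=O)[nH]c2cc(C3=CCOCC3)ccc12` keeps the shared core and exchanges only the group on the aromatic carbon: a group of 6 heavy atoms (5 carbon, 1 oxygen; one six-membered non-aromatic ring with 1 hetero atom) in place of a group of 7 heavy atoms (6 carbon, 1 fluorine; one six-membered aromatic ring of carbon only), on an aromatic carbon. All three measured steps are exchanges at this same carbon, but each of them places an aromatic ring there, so none shows directly what a non-aromatic ring does. Two of them start from the limit: an at least 3.9-fold lower number from compound 1 to compound 2 (0.59 log units; beyond the scatter) and an at least 1.6-fold lower number from compound 1 to compound 3 (0.22 log units; that floor lies within the scatter). Among the measured compounds shown here, the only step between two actual numbers is a 2.4-fold higher number from compound 2 to compound 3 (0.37 log units; beyond the scatter).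

Since that step is modest and the data fix no direction for the new ring, no clear change is expected in this assay. The expected step is a 1.2-fold lower number from compound 3 to compound 4 (0.08 log units; within the scatter), which would remain within the scatter. For compound 4 the estimated value is 10000 nM, with an expected range from 4500 nM to 20000 nM.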

Compound 4, half-maximal inhibitory concentration: 10500 nM
Compound 4: middle estimate off by 1.1-fold (0.02 log units), on the low side; low and high end bracket the measured number.
By their numbers in this assay, from the lowest: compound 2; then compounds 4 and 3 (each within the scatter of the next). At a limit, above all of these: compound 1.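

In this assay, among the compounds shown here, compound 4 puts a non-aromatic ring on this aromatic carbon for the first time, and a 1.1-fold lower number from compound 3 to compound 4 (0.06 log units; within the scatter), so its number cannot be told apart from that of compound 3 and, in this pair, an aromatic ring at this place is not needed to hold the number. Thiophen-3-yl keeps a small lead over the new ring, with a 2.1-fold higher number from compound 2 to compound 4 (0.31 log units; beyond the scatter), which means that compound 2 stays apart from both six-membered replacements, whether aromatic or not. Compound 1 stands at a limit of the assay and not a number, so an at least 1.9-fold lower number from compound 1 to compound 4 (0.27 log units; that floor lies within the scatter) gives only a floor: the limit of > 20000 nM in this assay, at which 1 of the 4 values shown sits.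

The compounds shown leave open whether the ring oxygen of compound 4 matters, as a cyclohexenyl ring with carbon in its place would test, and whether the double bond matters, as a fully saturated tetrahydropyranyl ring would test. They also leave open what an amine, such as a piperidine ring, or a carboxylic acid at this carbon would do to the number.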